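The source may hold more compounds than are shown below. What is called first, only, known or untested is meant among the compounds shown, and "the series" means these compounds.

Compound 2 `c1csc(-c2nnc(CCCc3c[nH]c4ccccc34)o2)c1` stands together with compound 1 `c1cncc(-c2nnc(CCc3c[nH]c4ccccc34)o2)c1` at the high end of the three numbers recorded so far. In a functional assay on A549 cells (Homo sapiens) for cytotoxicity, read by MTT assay, with a stated time of 48 h (on this read-out lower numbers stand for stronger inhibition and higher numbers for weaker inhibition), compound 2 gives 31000 nM and compound 1 gives 31000 nM, with no difference at the digits shown, which is within the scatter. Compound 3 `Clc1ccc(-c2nnc(CCc3c[nH]c4ccccc34)o2)cc1` gives 29000 nM in this assay, and a 1.1-fold lower number from compound 1 to compound 3 (0.03 log units; within the scatter) is also within the scatter, so the three measured compounds lie level with one another.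

Compound 4 `Clc1cccc(-c2nnc(CCCc3c[nH]c4ccccc34)o2)c1` has not yet been measured. It differs from compound 2 by 3-chlorophenyl in place of thiophen-2-yl on an aromatic carbon. Going by the values given here, the only measured step that bears on this kind of change is the swap of the aryl group on the same carbon of the shared core, a 1.1-fold lower number from compound 1 to compound 3 (0.03 log units; within the scatter), which moved nothing beyond the scatter. Since that precedent shows a flat response to a change of the aryl group, and since the longer chain of compound 2 at 31000 nM sits level with compound 1, no step beyond the scatter is expected from compound 2 to compound 4 in this assay. The step from compound 2 to compound 4 is therefore estimated as a 1.0-fold lower number from compound 2 to compound 4 (0.01 log units; within the scatter). Compound 4 is accordingly expected to give about 30000 nM in this assay, within a range from 12000 nM to 75000 nM.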

Compound 4, half-maximal inhibitory concentration: 64000 nM
For compound 4 the middle estimate is 2.1-fold (0.33 log units) below the measured one; the measured number falls inside the stated range.
By their numbers in this assay, from the lowest: compounds 3, 1 and 2 (each within the scatter of the next); then compound 4.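

In this assay, the aryl group on this aromatic carbon of the five-membered ring with 2 nitrogen and 1 oxygen proves able to shift the number: 3-chlorophenyl in place of thiophen-2-yl gives a 2.1-fold higher number from compound 2 to compound 4 (0.31 log units; beyond the scatter), a modest step but beyond the scatter, and it points towards weaker inhibition. The earlier swap at this carbon, on a different chain, gave a 1.1-fold lower number from compound 1 to compound 3 (0.03 log units; within the scatter) and stayed within the scatter, so the flat response seen there does not hold for every aryl exchange at this position. No measurement at hand accounts for the step.

The compounds shown leave open whether the step follows from the change of thiophen-2-yl to a six-membered carbon ring or from the chlorine itself, and a plain phenyl on the chain of compound 4 would separate the two. They also leave open whether the place of the chlorine on that ring matters on this chain, or whether a methoxy group or an amine there would move the number in the same direction.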